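Swapping Ethylamino for Methoxy on the Fused Ring

The compounds below may be only part of what the source reports. "The series", "measured", "known", "first", "only" and "open" are said of these compounds alone.

Measured so far:
compound 1, `CCNc1ccc2c(c1)OC(N)=C(C#N)C2c1cc(Br)c(OC)c(OC)c1`: 14000000 nM
compound 2, `CCNc1ccc2c(c1)OC(N)=C(C#N)C2c1cc(OC)cc(OC)c1`: 61700000 nM
compound 3, `COc1ccc2c(c1)OC(N)=C(C#N)C2c1cc(Br)c(OC)c(OC)c1`: 17000000 nM

These three compounds were tested in a functional assay on T47D cells (Homo sapiens) for activation; a higher number here means that more compound is needed for the effect, a lower number that less compound is needed. Compound 4, `COc1cc(OC)cc(C2C(C#N)=C(N)Oc3cc(OC)ccc32)c1`, has not been measured. The change from compound 1 to compound 3, (methoxy in place of ethylamino on an aromatic carbon), gave a 1.2-fold higher number from compound 1 to compound 3 (0.08 log units; within the scatter). The change from compound 2 to compound 4 is the same one, (methoxy in place of ethylamino on an aromatic carbon). The difference between the core of compound 1 and the core of compound 2 is not broken down here. Since compound 2 is the parent here, and since the same change once barely moved the number, the step is expected to be a 1.1-fold higher number from compound 2 to compound 4 (0.05 log units; within the scatter). Compound 4 is therefore estimated at 70000000 nM, probably between 25000000 nM and 200000000 nM.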

Compound 4, half-maximal effective concentration: 15000000 nM
Compound 4: middle estimate off by 4.7-fold (0.67 log units), on the high side; the measured number lies below the stated range.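

In this assay, putting methoxy in place of ethylamino gave a 4.1-fold lower number from compound 2 to compound 4 (0.61 log units; beyond the scatter). The same change therefore does not carry over unchanged from one core to the other, since the two steps differ: the same change on two cores in this assay, a 1.2-fold higher number (0.08 log units; within the scatter) from compound 1 to compound 3 and a 4.1-fold lower number (0.61 log units; beyond the scatter) from compound 2 to compound 4, 5.0-fold (0.70 log units) apart, beyond the scatter of two such steps This rests on a single pair for each core, so it does not show which feature of the cores separates the two results, or how the change would behave on a further core.

The compounds shown leave open how other groups on this aromatic carbon, such as a hydroxyl or the longer propylamino, would behave. They also leave open whether such groups would differ between the core of compound 1 and the core of compound 2.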